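The source may report more compounds than this note shows. Statements on the series, on what has been measured and on what is new or still open speak of the compounds shown alone.

Working notes on the series. The three measured compounds share one core and differ only in the acyl or sulfonyl group on the cyclohexyl amine. Compound 1 `CCCN(CC[C@H]1CC[C@H](NC(=O)/C=C/c2ccc(F)cc2)CC1)[C@H]1CCc2nc(N)sc2C1` carries a fluorinated cinnamamide; in an assay on brain for displacement of a labelled ligand from D(3) dopamine receptor (Rattus norvegicus) (a higher number here means a weaker inhibitor, a lower number a stronger inhibitor), compound 1 gives 1 nM. Compound 2 `CCCN(CC[C@H]1CC[C@H](NC(=O)c2ccc(-c3noc(C(C)C)n3)cc2)CC1)[C@H]1CCc2nc(N)sc2C1` carries a benzamide bearing an isopropyl-oxadiazole; in this assay compound 2 gives 2 nM. Compound 3 `CCCN(CC[C@H]1CC[C@H](NS(=O)(=O)c2ccc(-c3ccccc3)cc2)CC1)[C@H]1CCc2nc(N)sc2C1` is the only sulfonamide, with a 4-phenylphenyl on the sulfonyl sulfur; in this assay compound 3 gives 41 nM, the highest of the three numbers, beyond the scatter from both others, nearest to compound 2 and furthest from compound 1, so compound 3 is the weakest of the measured set.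

Compound 4 `CCCN(CC[C@H]1CC[C@H](NS(=O)(=O)c2ccc(Cl)nc2)CC1)[C@H]1CCc2nc(N)sc2C1` keeps the sulfonamide and changes only the aryl: 6-chloropyridin-3-yl in place of 4-phenylphenyl on a sulfonyl sulfur. For the measured compounds named here, no measured pair isolates a change of this kind, so nothing in the data fixes its size or direction. The expectation rests on compound 3 alone, which already gives 41 nM in this assay. A modest step toward a higher number is expected, with wide uncertainty, and the estimated step is a 2.9-fold higher number from compound 3 to compound 4 (0.47 log units; beyond the scatter). Compound 4 is expected at 120 nM, within a range of 30 nM to 500 nM.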

Compound 4, inhibition constant: 0.63 nM
Compound 4: middle estimate off by 190-fold (2.28 log units), on the high side, and the stated range ends above it.
By their numbers in this assay, from the lowest: compounds 4, 1 and 2 (each within the scatter of the next, the first and the last beyond it); then compound 3.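

On a sulfonyl sulfur the aryl group decides a great deal in this assay: 6-chloropyridin-3-yl in place of 4-phenylphenyl gives a 65-fold lower number from compound 3 to compound 4 (1.81 log units; beyond the scatter) and so ties the high number of compound 3 to that sulfonamide with its aryl, not to the sulfonamide as such. A sulfonyl link on the amine nitrogen is also compatible with a number as low as an acyl link gives, since (6-chloropyridin-3-yl)sulfonyl in place of (2-(4-fluorophenyl)ethenyl)carbonyl gives a 1.6-fold lower number from compound 1 to compound 4 (0.20 log units; within the scatter) and the two compounds cannot be told apart. Nothing on hand offers an explanation for either step.

From the compounds shown here alone, the step from compound 3 changes the number of rings, the ring nitrogen and the chlorine all at once, so which of these changes carries it stays open. Also open, going by these compounds, are how a plain phenyl, a methoxypyridine or a butyl chain on the sulfonyl sulfur would stand, and whether the low number of compound 4 in this assay carries over to other dopamine receptors.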